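The source may hold more compounds than are shown below. What is called first, only, known or untested is meant among the compounds shown, and "the series" means these compounds.

Compound 1 `ClCc1ccc(Cn2cnc3nc(Cl)nc(Cl)c32)cc1` is the weaker of the two compounds for which a number is available: in a functional assay on SNB-19 cells (Homo sapiens) for cytotoxicity, read by sulforhodamine B assay, with a stated time of 48 h (on this read-out lower numbers stand for stronger inhibition of growth and higher numbers for weaker inhibition of growth), compound 1 gives 29500 nM. Compound 2 `ClCc1cccc(Cn2cnc3c(Cl)nc(Cl)nc32)c1` gives 1950 nM in this assay, and the gap between compound 1 and compound 2 lies well beyond the scatter. Compound 3 `ClCc1ccccc1Cn1cnc2nc(Cl)nc(Cl)c21` has no reported result in this assay, its entry being "not determined" (no result reported).

Compound 4 `ClCc1ccc(Cn2cnc3ncnc(Cl)c32)cc1` differs from compound 1 in one place: hydrogen in place of chloro on an aromatic carbon. For the measured compounds named here, no pair of measured compounds shows the effect of this change on the shared core, so the size of the step cannot be read from the data. Removing a chloro from the core while keeping the chloromethyl-substituted benzyl group of compound 1 is expected to change growth inhibition little, or to weaken it somewhat, with a step from compound 1 to compound 4 estimated at a 1.7-fold higher number from compound 1 to compound 4 (0.23 log units; within the scatter). The value of compound 4 in this assay is therefore estimated at 50000 nM, with a plausible range from 12000 nM to 200000 nM.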

Compound 4, concentration for 50% growth inhibition: 1690 nM
For compound 4 the middle estimate is 30-fold (1.47 log units) above the measured one, outside the stated range (below it).
By their numbers in this assay, from the lowest: compounds 4 and 2 (each within the scatter of the next); then compound 1.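

In this assay, for the compounds shown here, hydrogen in place of chloro on the aromatic carbon between two ring nitrogen atoms gives a 17-fold lower number from compound 1 to compound 4 (1.24 log units; beyond the scatter), the first step between compounds that differ in one place. It shows that this position has a large effect on growth inhibition in the setting of compound 1, and that here the compound without the chloro is the stronger inhibitor. Nothing available explains why the step is so large.

On these data alone, whether a different group at this position, such as an amine or a methoxy group, would give stronger or weaker growth inhibition than hydrogen remains open. Also open, as far as these compounds go, are the contribution of the remaining chloro on the core of compound 4 and whether the same change would have a similar effect in compound 2 or compound 3.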